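This account rests on a few compounds, and the source may have more. Where it says the series, first, only, none or still open, it means among the compounds named here.

Measured so far in a functional assay on MGC-803 cells (Homo sapiens) for antiproliferative activity, read by MTT assay, with a stated time of 48 h; a lower number here means a stronger inhibitor, a higher number a weaker inhibitor:
- compound 1 `COc1ccc(CN(C(=O)CSc2nc3ccccc3s2)c2cc(OC)c(OC)c(OC)c2)cc1[N+](=O)[O-]` gives 682 nM
- compound 2 `COc1cc(CN(C(=O)CSc2nc3ccccc3s2)c2cc(OC)c(OC)c(OC)c2)cc(OC)c1OC` gives 45700 nM
- compound 3 `COc1ccc(CN(C(=O)CSc2nc3cc(Cl)ccc3s2)c2cc(OC)c(OC)c(OC)c2)cc1O` gives 85 nM

Compound 1 holds the middle place of these three numbers, with compound 3 lower and compound 2 higher. Compound 4 `COc1ccc(CN(C(=O)CSc2nc3ccccc3s2)c2cc(OC)c(OC)c(OC)c2)cc1C(F)(F)F` is still unmeasured. It keeps the core of compound 1 and changes one group, trifluoromethyl in place of nitro on an aromatic carbon, ortho to a methoxy group: trifluoromethyl in place of nitro on an aromatic carbon.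

Within the data shown here, one measured step touches this aryl group: a 67-fold higher number from compound 1 to compound 2 (1.83 log units; beyond the scatter). That step is large, but it exchanges the whole 4-methoxy-3-nitrophenyl group for 3,4,5-trimethoxyphenyl, so it shows that the readout can respond to this part of the molecule without giving the size of a single-group exchange. Compound 3 carries a hydroxyl where compound 1 carries nitro, and it also differs on the core, so the lower number of compound 3, 85 nM, cannot be assigned to either place. Among the measured compounds shown here, no measured step isolates the nitro group. A moderate rise in this assay is therefore expected, possibly not beyond the scatter, and the uncertainty is wide.

The expected change is a 2.1-fold higher number from compound 1 to compound 4 (0.31 log units; beyond the scatter). For compound 4 the estimate is 1400 nM, with an expected range from 300 nM to 7000 nM.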

Compound 4, half-maximal inhibitory concentration: 25200 nM
Compound 4: the middle estimate sits 18-fold (1.26 log units) below what was measured; the whole stated range lies below it.
By their numbers in this assay, from the lowest: compound 3; then compound 1; then compounds 4 and 2 (each within the scatter of the next).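

In this assay the exchange of a single group, trifluoromethyl in place of nitro on an aromatic carbon ortho to a methoxy group, gives a 37-fold higher number from compound 1 to compound 4 (1.57 log units; beyond the scatter) and so shows that this one place can carry a large step on its own, which the exchange of the whole aryl group could not show. Among these compounds, replacing that whole group gives a 67-fold higher number from compound 1 to compound 2 (1.83 log units; beyond the scatter) while the remaining comparison gives a 1.8-fold lower number from compound 2 to compound 4 (0.26 log units; within the scatter) and therefore does not separate 4-methoxy-3-(trifluoromethyl)phenyl from 3,4,5-trimethoxyphenyl, leaving 4-methoxy-3-nitrophenyl as the one aryl group apart from these two among the compounds on the unchlorinated core. The data at hand offer no measurement that accounts for the size of the step from nitro to trifluoromethyl.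

Going by these compounds, whether nitro is singular at this place or is one of several groups that keep the number low stays open, and the hydroxyl of compound 3 cannot settle this while it also differs on the core from compound 1. On these data alone, what a nitrile, an amine or a carboxylic acid would give at this place on the core of compound 1 also stays open.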